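A Methyl Group Removed From the Ring Nitrogen

The compounds below may be only part of what the source reports. "The series", "measured", "known", "first", "only" and "open" are said of these compounds alone.

- compound 1 `CCCCCCCCCCCC(CCO)n1cnc2c(Cl)ncnc21` gives 5290 nM
- compound 2 `CCCCCCCCCCCC(CCO)n1cnc2c(NC)ncnc21` gives 12800 nM
- compound 3 `CCCCCCCCCCCC(CCO)n1cnc2c(N)ncnc21` has not yet been measured

Both values come from a functional assay on SW480 cells (Homo sapiens) for antiproliferative activity, read by MTT assay, with a stated time of 48 h; a higher number here means a weaker inhibitor, a lower number a stronger inhibitor. Compound 2 has the higher of the two numbers, which makes it the weaker inhibitor of the pair. Compound 3 differs from compound 2 in one place, with hydrogen in place of methyl on a nitrogen on an aromatic ring, so that methylamino becomes amino (hydrogen in place of methyl on a nitrogen on an aromatic ring).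

Among the measured compounds shown here, only one measured step bears on this change: a 2.4-fold higher number from compound 1 to compound 2 (0.38 log units; beyond the scatter). That modest step concerns the same group, but it replaced chloro and did not remove a methyl, so it offers only a rough sense of scale. For the measured compounds named here, no measured pair shows what losing this methyl does on its own. A step beyond the scatter in this assay is therefore not expected, and no direction is favoured with any confidence. The estimate is a 1.2-fold lower number from compound 2 to compound 3 (0.07 log units; within the scatter). For compound 3 the expected value is 11000 nM, with an expected range of 5000 nM to 24000 nM.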

Compound 3, half-maximal inhibitory concentration: 11600 nM
Estimate against measurement, compound 3: 1.1-fold (0.02 log units) below; the measured number falls inside the stated range.
By their numbers in this assay, from the lowest: compound 1; then compounds 3 and 2 (each within the scatter of the next).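

In this assay, hydrogen in place of methyl on this nitrogen gives a 1.1-fold lower number from compound 2 to compound 3 (0.04 log units; within the scatter) and so has no effect that can be told from ordinary assay variation: among the compounds shown, this methyl neither adds to nor takes away from the measured activity. Amino in place of chloro on the same aromatic carbon gives a 2.2-fold higher number from compound 1 to compound 3 (0.34 log units; beyond the scatter) and is a modest loss, much like the step already seen with methylamino, so compound 1 remains the strongest inhibitor of the three, while compound 2 and compound 3 cannot be ranked against each other. No supporting measurement is available to explain what lies behind these numbers.

The compounds shown leave open whether a larger group on this nitrogen, such as ethylamino or dimethylamino, would also match amino and methylamino, or would shift the activity. They also leave open whether another group in place of chloro, such as bromo or methoxy, would keep the lower number of compound 1, and what a shorter chain in place of the long one would do.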